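Fluoro in place of hydrogen on the bromophenyl arm

This account rests on a few compounds, and the source may have more. Where it says the series, first, only, none or still open, it means among the compounds named here.

Measured compounds:
Compound 1, `C=CCn1c(=O)/c(=C\c2ccc(Cl)c(Cl)c2)[nH]c(=O)/c1=C\c1ccccc1`: in a functional assay on HeLa cells (Homo sapiens) for cytotoxicity, read by CCK-8 assay, with a stated time of 72 h (on this read-out higher numbers stand for weaker inhibition and lower numbers for stronger inhibition), compound 1 is recorded as "not active" (no number reported), with no number given.
Compound 2, `C=CCn1c(=O)/c(=C\c2cccc(Br)c2)[nH]c(=O)/c1=C\c1ccccc1OC`: in this assay compound 2 gives 5400 nM.
Compound 3, `COc1ccccc1/C=c1/[nH]c(=O)/c(=C\c2nc[nH]c2C(C)(C)C)[nH]c1=O`: in this assay compound 3 gives 80 nM.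

Compound 2 stands at the higher of the two numbers reported in this assay; compound 3 lies far below it, and the gap between the two is beyond the usual scatter. Compound 1 contributes no number against which compound 2 can be placed.

Compound 4, `C=CCn1c(=O)/c(=C\c2cc(Br)ccc2F)[nH]c(=O)/c1=C\c1ccccc1OC`, has not yet been measured in this assay. It differs from compound 2 in one place:
fluoro in place of hydrogen on an aromatic carbon

Going by the values given here, no pair of measured compounds differs by this kind of change, so nothing in the data shows how a single fluoro entering at this place shifts the read-out. A single small atom added to the 3-bromophenyl arm is expected to leave the number close to that of compound 2, within the usual scatter. The step of a 1.4-fold lower number from compound 2 to compound 4 (0.13 log units; within the scatter) is therefore estimated to be small, leaning if anything toward a slightly lower number. Compound 4 is expected to give about 4000 nM in this assay, in a range from 1500 nM to 12000 nM.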

Compound 4, half-maximal inhibitory concentration: 34600 nM
Estimate against measurement, compound 4: 8.7-fold (0.94 log units) below; measured number outside the range, above it.
By their numbers in this assay, from the lowest: compound 3; then compound 2; then compound 4.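

In this assay, the single fluoro that turns the 3-bromophenyl arm into a 5-bromo-2-fluorophenyl arm gives a 6.4-fold higher number from compound 2 to compound 4 (0.81 log units; beyond the scatter) and so moves the read-out toward weaker inhibition, a step beyond the scatter. This aromatic carbon, ortho to a large group and para to the bromo group, is therefore not indifferent to substitution: one heavy atom entering there, with no hydrogen-bond donor or acceptor and no net charge, is enough to shift the number. Going by these compounds alone, the earlier compounds offered no pair differing in one place, so this is the first single change whose effect can be read, and nothing measured here explains the shift.

The compounds shown leave open whether this rise belongs to fluoro itself or would also follow from another group on the same carbon, such as a hydroxyl, an amine or a methyl. They also leave open whether fluoro on a different carbon of this arm, or on the 2-methoxyphenyl arm, would move the number in the same direction.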